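Aryl ketone swap on the benzyl hydroxamate series

This account rests on a few compounds, and the source may have more. Where it says the series, first, only, none or still open, it means among the compounds named here.

Measured so far in an assay on isolated protein for inhibition of polyamine deacetylase HDAC10 (Homo sapiens); on this read-out lower numbers stand for stronger inhibition and higher numbers for weaker inhibition:
Compound 1 `COc1cc(C(=O)c2ccc3c(ccn3S(=O)(=O)c3ccc(/C=C/C(=O)NO)cc3)c2)cc(OC)c1OC` gives > 100000 nM, which is a limit of the assay.
Compound 2 `COc1ccc(C(=O)c2ccc3c(ccn3S(=O)(=O)c3ccc(/C=C/C(=O)NO)cc3)c2)cc1` gives > 100000 nM, also a limit of the assay.
Compound 3 `COc1ccc(C(=O)c2ccc3c(ccn3Cc3ccc(C(=O)NO)cc3)c2)cc1OC` gives 18900 nM.

Going by the values given here, compound 3 therefore stands as the only compound in this assay with an actual number; the other two values are limits. Among the compounds with values here, the single step between measured compounds that differ in one place, a step that the two limits leave unreadable from compound 1 to compound 2, stays unreadable because of the limit of > 100000 nM in this assay, at which 2 of the 3 values shown sit. Compound 1 and compound 2 share a sulfonyl linker and cinnamoyl hydroxamate not present in compound 3, so their values show only that both sit at the limit.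

Compound 4 `O=C(NO)c1ccc(Cn2ccc3cc(C(=O)c4ccc(F)cc4)ccc32)cc1` is not yet measured. It differs from compound 3 by 4-fluorophenyl in place of 3,4-dimethoxyphenyl on a carbonyl carbon. Within the data shown here, no measured step covers this change; the one step available, a step that the two limits leave unreadable from compound 1 to compound 2, also alters the methoxy pattern on the aryl ketone but has no readable size, and it sits on a different linker. With nothing pointing either way, no change beyond the scatter is expected in this assay. Compound 4 is expected to give about 20000 nM, between 6000 nM and 60000 nM. The expected step is thus a 1.1-fold higher number from compound 3 to compound 4 (0.02 log units; within the scatter), within the usual scatter.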

Compound 4, half-maximal inhibitory concentration: > 100000 nM
Compound 4 was reported as a limit; the forecaster's own chance of this, stated with the estimate: 20%; middle value at least 5.0-fold (0.69 log units) from the limit.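

In this assay, the aryl group on the carbonyl carbon is not a silent position on the core of compound 3: 4-fluorophenyl in place of 3,4-dimethoxyphenyl gives an at least 5.2-fold higher number from compound 3 to compound 4 (0.72 log units; beyond the scatter). Going by these compounds alone, this is the first readable step for a change of aryl group on this carbonyl carbon, since the step from compound 1 to compound 2, which also changes that aryl group, cannot be read. The size printed for the new step is only a lower bound, and how far the loss really goes cannot be told, because of the assay ceiling: the limit of > 100000 nM in this assay, at which 3 of the 4 values shown sit.

The change removes both methoxy groups and brings in a fluorine in one move, so the compounds shown do not tell whether the methoxy groups, the fluorine or both account for the step, and compound 3, at 18900 nM, remains the only compound with an actual number. As far as these compounds go, it stays open whether a plain phenyl, a single methoxy group, or a larger replacement such as a morpholine on this aryl ring would hold a readable value on the same core.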